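Isopropyl for Methyl on an Aromatic Nitrogen

The source may hold more compounds than are shown below. What is called first, only, known or untested is meant among the compounds shown, and "the series" means these compounds.

Measured so far:
compound 1, `COc1ccc(Nc2nccc(-c3cn(C)c4ccccc34)n2)c(OC)c1`: 940 nM
compound 2, `CNc1nc(C)c(-c2ccnc(Nc3ccc(OC)cc3OC)n2)s1`: 1470 nM
compound 3, `Oc1ccccc1Nc1nccc(-c2c[nH]c3ccccc23)n1`: 890 nM

In an assay on cells for inhibition of MAP kinase-interacting serine/threonine-protein kinase 1 (Homo sapiens), read by TR-FRET (a higher number here means a weaker inhibitor, a lower number a stronger inhibitor), compound 1 gives 940 nM, the second highest of the three numbers. Compound 3 gives 890 nM and compound 2 gives 1470 nM; both lie within the scatter of compound 1, so the three compounds cannot be told apart on these numbers. Compound 4, `COc1ccc(Nc2nccc(-c3cn(C(C)C)c4ccccc34)n2)c(OC)c1`, has not yet been measured. It differs from compound 1 in one place: isopropyl in place of methyl on an aromatic nitrogen. Among the compounds with values here, no measured pair shows a change of this kind, so nothing guides the size of the step. Compound 3 carries no group on that aromatic nitrogen yet gives 890 nM, within the scatter of compound 1, which suggests the group there matters little. Compound 4 is therefore expected to give 1000 nM, between 300 nM and 3500 nM. The step this estimate means, a 1.1-fold higher number from compound 1 to compound 4 (0.03 log units; within the scatter), is expected to stay within the scatter.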

Compound 4, inhibition constant: 710 nM
For compound 4 the middle estimate is 1.4-fold (0.15 log units) above the measured one; measured number inside the range.
By their numbers in this assay, from the lowest: compounds 4, 3, 1 and 2 (each within the scatter of the next, the first and the last beyond it).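

In this assay, within the data shown here, the step of a 1.3-fold lower number from compound 1 to compound 4 (0.12 log units; within the scatter) is the first measured for a single change at this aromatic nitrogen. It shows that isopropyl in place of methyl leaves the number within the scatter, so this position accepts the branched group with no measurable loss or gain. Nothing measured here explains this result. Still open, going by these compounds, is whether a longer chain, a phenyl ring or a chain ending in an amine or a carboxylic acid on this nitrogen would also stay within the scatter. On these data alone, the same single change on the other cores also remains open.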